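The source may hold more compounds than are shown below. What is called first, only, known or untested is meant among the compounds shown, and "the series" means these compounds.

Of the compounds shown here, two built on a shared core have been measured in an assay on isolated protein for inhibition of Rho-associated protein kinase 1 (Homo sapiens), read by scintillation counting, radiometric assay and 33P incorporation, with a stated time of 40 min, in the presence of a further agent that is not named here; on this read-out lower numbers stand for stronger inhibition and higher numbers for weaker inhibition. Compound 1 `CN(C)c1ccc(C(=O)Nc2cccc(NC(=O)COc3ccc4c(c3)CCC(=O)N4)c2)cc1` gives no number at all: in this assay compound 1 returns > 10000 nM, which is a limit of the measurement rather than a value. Compound 2 `COc1ccc(C(=O)Nc2cccc(NC(=O)COc3ccc4c(=O)ccoc4c3)c2)cc1` does give a number: in this assay compound 2 gives 18 nM. Among everything shown, that is the only genuine number. The other entry sits at the limit described by the limit of > 10000 nM in this assay, at which 1 of the 2 values shown sits.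

Compound 3 `O=C(COc1ccc2c(=O)ccoc2c1)Nc1cccc(NC(=O)c2cnc(C(F)(F)F)s2)c1` has not yet been measured. It differs from compound 2 in a single place: 2-(trifluoromethyl)-1,3-thiazol-5-yl in place of 4-methoxyphenyl on a carbonyl carbon. Within the data shown here, no pair of measured compounds separated by one change is available, so there is no measured step to lean on, and the expectation rests on the number for compound 2 alone. A moderate weakening is expected, with the change estimated as a 2.2-fold higher number from compound 2 to compound 3 (0.35 log units; beyond the scatter). In this assay compound 3 is therefore expected to give about 40 nM, within an estimated range from 10 nM to 200 nM.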

Compound 3, half-maximal inhibitory concentration: 160 nM
Beside the measured number, compound 3's estimate is 4.0-fold (0.60 log units) below it; low and high end bracket the measured number.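

Among these compounds, putting 2-(trifluoromethyl)-1,3-thiazol-5-yl in place of 4-methoxyphenyl on this carbonyl carbon gives an 8.9-fold higher number from compound 2 to compound 3 (0.95 log units; beyond the scatter) in this assay, and this is the first measured step at this place. It shows that the number responds to the group held here, and that a five-membered aromatic ring with 2 hetero atoms can replace the six-membered ring of carbon only while compound 3 still gives a real number, 160 nM. Nothing measured here accounts for the size of this step.

As far as these compounds go, the change swaps the ring and adds trifluoromethyl at once, and it remains open which of the two drives the step: a 1,3-thiazol-5-yl group without the trifluoromethyl, or a phenyl ring carrying trifluoromethyl, would separate them. From the compounds shown here alone, it is also open how this position responds to quite different groups on the same carbonyl carbon, such as a pyridine ring, a ring bearing a carboxylic acid, or a saturated ring such as cyclohexyl.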